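The source may hold more compounds than are shown below. What is called first, only, known or untested is meant among the compounds shown, and "the series" means these compounds.

Compound 3 `CC[C@H](C)[C@H](NC(=O)CN(c1nc(Cl)nc2[nH]cnc12)C1CC1)C(=O)OCc1ccccc1` stands lowest of the three numbers in a functional assay on the whole organism (Tail, strain ICR) with Mus musculus as the target, in the tail flick test, with a stated time of 120 min, at a dose of 25 umol/kg by the oral route (on this read-out higher numbers stand for a stronger effect at the one dose given and lower numbers for a weaker effect), giving 22%, though its gaps to the others fall inside the scatter: compound 1 `CC(C)[C@H](NC(=O)CN(c1nc(Cl)nc2[nH]cnc12)C1CC1)C(=O)OCc1ccccc1` gives 27.3% and compound 2 `C[C@@H](O)[C@H](NC(=O)CN(c1nc(Cl)nc2[nH]cnc12)C1CC1)C(=O)OCc1ccccc1` gives 30.7%. Compound 4 `CC(C)C[C@H](NC(=O)CN(c1nc(Cl)nc2[nH]cnc12)C1CC1)C(=O)OCc1ccccc1` is obtained from compound 3 by isobutyl in place of sec-butyl on a saturated chain carbon bound to an amide-type nitrogen and a carbonyl carbon. All three measured steps bear on this, since each exchanged a small group at the same kind of position: a number 3.4 percentage points higher from compound 1 to compound 2 (within the scatter), a number 5.3 percentage points lower from compound 1 to compound 3 (within the scatter) and a number 8.7 percentage points lower from compound 2 to compound 3 (within the scatter). None of them reached beyond the scatter, so the move from sec-butyl to isobutyl is also expected to give no step beyond the scatter, a number 3 percentage points higher from compound 3 to compound 4 (within the scatter). Compound 4 is therefore estimated at 25%, with a range from 14% to 37%.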

Compound 4, a percentage reported as activity, at one dose (the size of the read-out at that dose, not a potency): 8.58%
Beside the measured number, compound 4's estimate is 16.4 percentage points above it; measured number outside the range, below it.
By their numbers in this assay, from the lowest: compound 4; then compounds 3, 1 and 2 (each within the scatter of the next).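

Exchanging sec-butyl for isobutyl, the same atoms joined differently, gives a number 13.4 percentage points lower from compound 3 to compound 4 (beyond the scatter) in this assay, so this position responds to how the chain is built and not only to its atom count. Isobutyl in place of isopropyl gives a number 18.7 percentage points lower from compound 1 to compound 4 (beyond the scatter) and isobutyl in place of 1-hydroxyethyl gives a number 22.1 percentage points lower from compound 2 to compound 4 (beyond the scatter) in the same read-out, so isobutyl stands apart from all three other groups. No measurement available here explains this drop.

From the compounds shown here alone, a longer chain, such as n-hexyl, remains open at this position. So does a chain ending in an amine or a carboxylic acid.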